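Aryl Tetrazole to Cyclopropyl: a Step into Uncharted Ground

The source may report more compounds than this note shows. Statements on the series, on what has been measured and on what is new or still open speak of the compounds shown alone.

Three compounds share one core and differ only in the group on the tetrazole. Compound 1 `Cc1cc(NC(=O)Cn2nnc(-c3ccc(F)cc3)n2)n(C2CCCCC2)n1` carries a 4-fluorophenyl, compound 2 `Cc1cc(NC(=O)Cn2nnc(-c3cccc(F)c3)n2)n(C2CCCCC2)n1` a 3-fluorophenyl and compound 3 `COc1cccc(-c2nnn(CC(=O)Nc3cc(C)nn3C3CCCCC3)n2)c1` a 3-methoxyphenyl. In an assay on HEK293 cells for activation of Kir3.1/Kir3.2 (Homo sapiens), read by thallium flux (a higher number here means a larger maximal response, a lower number a smaller maximal response), compound 1 gives 92%, compound 2 gives 96% and compound 3 gives 76%. Compound 3 stands lowest of the three: the change is a number 16 percentage points lower from compound 1 to compound 3 (beyond the scatter) and a number 20 percentage points lower from compound 2 to compound 3 (beyond the scatter), whereas a number 4 percentage points higher from compound 1 to compound 2 (within the scatter).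

Compound 4 `Cc1cc(NC(=O)Cn2nnc(C3CC3)n2)n(C2CCCCC2)n1` differs from compound 3 by cyclopropyl in place of 3-methoxyphenyl on an aromatic carbon. Among the compounds with values here, none of the measured steps exchanges the aromatic ring itself; they only vary the substituent on it, and the methoxy-bearing compound 3 ends lowest. Replacing the whole 3-methoxyphenyl by cyclopropyl therefore lies outside what the measured steps cover, and the expectation rests on thin ground. A further modest fall is expected, as a number 11 percentage points lower from compound 3 to compound 4 (beyond the scatter), with wide uncertainty. Compound 4 is thus estimated in this assay at 65%, within a range of 35% to 95%.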

Compound 4, largest response reached (Emax), in percent of the reference or control that the assay uses: > 68%
Compound 4: no number, only a limit; the forecaster's own chance of this, stated with the estimate: 5%; at least 3 percentage points between middle value and limit.
By their numbers in this assay, from the lowest: compound 3; then compounds 1 and 2 (each within the scatter of the next).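

In this assay compound 4 gives > 68%, which is a limit and not a number. Its steps from compound 1, compound 2 and compound 3 cannot be read. The compounds shown leave open how large the maximal response of compound 4 actually is.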